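A few compounds are considered here, and "the series" means these few. Any claim that something is new, unique, unknown or untested is made for them only; others in the source may bear on it.

Values so far in a functional assay on PC-3 cells (Homo sapiens) (a higher number here means a weaker inhibitor of growth, a lower number a stronger inhibitor of growth), are these.

Compound 1 `O=S(=O)(/C=C/c1ccc(F)cc1)Cc1ccc(Nc2ncnc3ccccc23)cc1` gives 1000 nM
Compound 2 `O=S(=O)(/C=C/c1ccc(Cl)cc1)Cc1ccc(Nc2ncnc3ccccc23)cc1` gives 43000 nM
Compound 3 `O=S(=O)(/C=C/c1ccc(Cl)cc1Cl)Cc1ccc(Nc2ncnc3ccccc23)cc1` gives 19000 nM

Compound 3 at 19000 nM stands second highest of the three numbers, nearest to compound 2 and furthest from compound 1. Compound 4 `O=S(=O)(/C=C/c1ccc(F)cc1F)Cc1ccc(Nc2ncnc3ccccc23)cc1` differs from it by 2,4-difluorophenyl in place of 2,4-dichlorophenyl on a double-bonded chain carbon bound to a double-bonded chain carbon. The most direct evidence is the large step for chloro in place of fluoro on an aromatic carbon (a 43-fold higher number from compound 1 to compound 2 (1.63 log units; beyond the scatter)), which, read in reverse, points to a lower number for the fluoro compound. The whole-ring change is also large and runs the same way (a 19-fold higher number from compound 1 to compound 3 (1.28 log units; beyond the scatter)). Chloro in place of hydrogen on an aromatic carbon gave only a modest step (a 2.3-fold lower number from compound 2 to compound 3 (0.35 log units; beyond the scatter)). Going by the values given here, no measured compound carries 2,4-difluorophenyl, and the case for fluoro rests on compound 1 alone, so the range stays wide. A large move toward a lower number is therefore expected (a 13-fold lower number from compound 3 to compound 4 (1.10 log units; beyond the scatter)). In this assay compound 4 is estimated at 1500 nM (expected range 300 nM to 10000 nM).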

Compound 4, concentration for 50% growth inhibition: > 100000 nM
Compound 4: no number, only a limit; the forecaster's own chance of this, stated with the estimate: 3%; at least 66-fold (1.82 log units) between middle value and limit.
By their numbers in this assay, from the lowest: compound 1; then compound 3; then compound 2. At a limit, above all of these: compound 4.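

In this assay compound 4 stands at a limit, not at a number: the limit of > 100000 nM in this assay, at which 1 of the 4 values shown sits. At this place, on a double-bonded chain carbon bound to a double-bonded chain carbon, 2,4-difluorophenyl in place of 2,4-dichlorophenyl gives an at least 5.2-fold higher number from compound 3 to compound 4 (0.72 log units; beyond the scatter), so among these compounds fluoro does not by itself bring a lower number, and the low value belongs to the 4-fluorophenyl group of compound 1 alone. Adding a further halogen to the ring also works in opposite directions in the two available cases: chloro gives a 2.3-fold lower number from compound 2 to compound 3 (0.35 log units; beyond the scatter), whereas fluoro gives an at least 100-fold higher number from compound 1 to compound 4 (2.00 log units; beyond the scatter), and 2,4-difluorophenyl also ends up with an at least 2.3-fold higher number from compound 2 to compound 4 (0.36 log units; beyond the scatter).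

Going by these compounds, how far the true value of compound 4 lies past its limit stays unknown, so the size of these last steps has only a lower bound. The compounds shown also leave open whether 4-fluorophenyl is unusual or 4-chlorophenyl is the poor case, a question that plain phenyl, 4-methylphenyl or 4-methoxyphenyl at the same place would bear on.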